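The compounds below may be only part of what the source reports. "The series", "measured", "known", "first", "only" and "open" are said of these compounds alone.

Compound 1 `COC(=O)C[C@H](NC(=O)OC(C)(C)C)C(=O)N(Cc1ccc(F)cc1)C1(C(=O)NCc2ccccc2)CCN(C2CCCCC2)CC1`, measured in an ADME assay on MDCK cells (Canis lupus familiaris) for cytotoxicity, read by microscopy, with a stated time of 72 h (on this read-out higher numbers stand for lower toxicity in this test and lower numbers for higher toxicity in this test), gives 73000 nM.
Compound 2 `COC(=O)C[C@H](NC(=O)OC(C)(C)C)C(=O)N(Cc1ccc(F)cc1)C1(C(=O)NC2CCCCC2)CCN(Cc2ccccc2)CC1` gives 100000 nM.
Compound 3 `COC(=O)C[C@H](NC(=O)OC(C)(C)C)C(=O)N(C1CC1)C1(C(=O)NCc2ccccc2)CCN(Cc2ccccc2)CC1` gives 84000 nM.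

Among these three measured values, compound 3 stands second highest. Its nearest neighbour is compound 1, whose value lies within the scatter of that of compound 3, and the furthest is compound 2, which also lies within the scatter. The three compounds therefore cannot be separated on this read-out.

Compound 4 `COC(=O)C[C@H](NC(=O)OC(C)(C)C)C(=O)N(Cc1ccc(F)c(F)c1)C1(C(=O)NCc2ccccc2)CCN(Cc2ccccc2)CC1` differs from compound 3 in one place: 3,4-difluorobenzyl in place of cyclopropyl on an amide-type nitrogen. Within the data shown here, no measured pair shows this change, so nothing in the data says what it does. Given how closely compounds 1, 2 and 3 sit, only a small step is expected, a 1.3-fold lower number from compound 3 to compound 4 (0.11 log units; within the scatter), if anything towards a lower number. Compound 4 is estimated at 65000 nM, between 30000 nM and 100000 nM.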

Compound 4, minimum cytotoxic concentration: 20000 nM
For compound 4 the middle estimate is 3.3-fold (0.51 log units) above the measured one; the whole stated range lies above it.
By their numbers in this assay, from the lowest: compound 4; then compounds 1, 3 and 2 (each within the scatter of the next).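

In this assay the group on this amide-type nitrogen makes a measurable difference: 3,4-difluorobenzyl in place of cyclopropyl gives a 4.2-fold lower number from compound 3 to compound 4 (0.62 log units; beyond the scatter) and so a step beyond the scatter. Compound 1, compound 2 and compound 3 could not be separated and gave no such sign. Nothing available accounts for this step.

The change brings in the aromatic ring and both fluorines at once, so the compounds shown do not tell which of them goes with the lower number. From the compounds shown here alone, it also remains open whether a methyl or an unsubstituted benzyl on this nitrogen would stay with compound 3 or fall with compound 4.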